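Bromo for phenyl on the pyridinone-type core, compound 2 to 3

A few compounds are considered here, and "the series" means these few. Any claim that something is new, unique, unknown or untested is made for them only; others in the source may bear on it.

Working notes on the series. Compound 1 `O=C(NC1CCCCCC1)c1c(-c2ccccc2)c(Br)cn(Cc2ccc(F)cc2)c1=O` is measured in an assay on HEK293 cells for inhibition of Monoacylglycerol lipase ABHD6 (Homo sapiens), with stated times of 30 min and 5 min (a lower number here means a stronger inhibitor, a higher number a weaker inhibitor), and gives 3000 nM. Compound 2 `Cc1c(-c2ccccc2)cn(Cc2ccc(F)cc2)c(=O)c1C(=O)NC1CCCCCC1` is measured in the same this assay, and for compound 2 the read-out is only the limit of the assay, > 10000 nM; this sits at the limit of > 10000 nM in this assay, at which 1 of the 2 values shown sits. Among the measured compounds shown here, no step between these two compounds is counted, so only the two values themselves are stated: one a number, the other a limit. On the numbers shown, compound 2 stands at the weak end, beyond the top of the range of the assay.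

Compound 3 `Cc1c(Br)cn(Cc2ccc(F)cc2)c(=O)c1C(=O)NC1CCCCCC1` has not yet been measured in this assay. It differs from compound 2 in one place: bromo in place of phenyl on an aromatic carbon. For the measured compounds named here, since compound 2 gives only a limit, no counted step supports a firm prediction. The step from compound 2 to compound 3 is expected to move toward stronger inhibition, an at least 2.0-fold lower number from compound 2 to compound 3 (0.30 log units; that floor lies within the scatter), though it may not exceed the scatter. For compound 3 the estimate in this assay is 5000 nM, with a range from 1000 nM to 30000 nM.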

Compound 3, half-maximal inhibitory concentration: > 10000 nM
Compound 3: a limit, no number; the forecaster's own chance of this, stated with the estimate: 40%; at least 2.0-fold (0.30 log units) between middle value and limit.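

In this assay, among the compounds shown here, the single change made with the bromo kept gives an at least 3.3-fold higher number from compound 1 to compound 3 (0.52 log units; beyond the scatter), the first step that can be read. The step for bromo in place of phenyl, on the aromatic carbon ortho to a methyl group, cannot be read, as both of its ends are limits of the assay and not numbers. Of the compounds shown, only compound 1, with phenyl where compound 3 carries methyl, gives a number, and the other two compounds stand at the top of the range: the limit of > 10000 nM in this assay, at which 2 of the 3 values shown sit.

Going by these compounds, how far compound 2 and compound 3 lie beyond that limit stays open, and with it any ranking of phenyl against bromo at the carbon ortho to a methyl group. For the compounds shown here, also open is whether phenyl is the only group at the methyl-bearing carbon that keeps a number within the range of the assay, or whether an ethyl, a methoxy, a dimethylamino or a pyridyl group there would do the same with the bromo kept.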